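Changing the aromatic arm of compound 3

This account rests on a few compounds, and the source may have more. Where it says the series, first, only, none or still open, it means among the compounds named here.

Three compounds have been measured in a functional assay on CHO-K1 cells for antagonist activity at C-X-C chemokine receptor type 3 (Homo sapiens), read by FLIPR, with a stated time of 10 min; a higher number here means a weaker inhibitor, a lower number a stronger inhibitor:

Compound 1 `Cc1ncc(-c2nc(C(F)(F)F)sc2N2CCN(C(=O)Cn3nc(C)nc3C)[C@H](C)C2)cn1`: 19 nM
Compound 2 `Cc1nc(C)n(CC(=O)N2CCN(c3sc(C(F)(F)F)nc3-c3cnc(C4CC4)nc3)C[C@H]2C)n1`: 3.5 nM
Compound 3 `Cc1nc(C)n(CC(=O)N2CCN(c3sc(C(F)(F)F)nc3-c3cnc(N4CCCC4)nc3)C[C@H]2C)n1`: 3.5 nM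

Compound 3 stands level with compound 2 and together with it gives the lowest numbers of the three; compound 1 sits a step above, a 5.4-fold lower number from compound 1 to compound 3 (0.73 log units; beyond the scatter).

Compound 4 `Cc1nc(C)n(CC(=O)N2CCN(c3sc(C(F)(F)F)nc3-c3ccc(C(F)(F)F)nc3)C[C@H]2C)n1` differs from compound 3 in one place: 6-(trifluoromethyl)pyridin-3-yl in place of 2-(pyrrolidin-1-yl)pyrimidin-5-yl on an aromatic carbon. Within the data shown here, no measured step covers this exact exchange. The steps that touch the same position, a 5.4-fold lower number from compound 1 to compound 2 (0.73 log units; beyond the scatter) and a 5.4-fold lower number from compound 1 to compound 3 (0.73 log units; beyond the scatter), show that this arm does move the number, while no change at the digits printed from compound 2 to compound 3 (within the scatter) shows two larger groups landing at the same level. Because of a 5.4-fold lower number from compound 1 to compound 3 (0.73 log units; beyond the scatter), a change in this arm is expected to cost some potency, so compound 4 is estimated at 10 nM (range 3 nM to 40 nM), an expected step of a 2.9-fold higher number from compound 3 to compound 4 (0.46 log units; beyond the scatter).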

Compound 4, half-maximal inhibitory concentration: 4.2 nM
For compound 4 the middle estimate is 2.4-fold (0.38 log units) above the measured one; the range from low to high includes it.
By their numbers in this assay, from the lowest: compounds 2, 3 and 4 (each within the scatter of the next); then compound 1.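

A pyrimidine ring is not needed to reach this level: 6-(trifluoromethyl)pyridin-3-yl, with a single ring nitrogen and no pyrrolidine or cyclopropyl, gives a 1.2-fold higher number from compound 3 to compound 4 (0.08 log units; within the scatter) and a 1.2-fold higher number from compound 2 to compound 4 (0.08 log units; within the scatter). Set against 2-methylpyrimidin-5-yl, this third larger arm gives a 4.5-fold lower number from compound 1 to compound 4 (0.66 log units; beyond the scatter), so all three larger arms shown differ from the methyl-bearing one in the same direction.

Nothing measured here explains why these three arms land together. As far as these compounds go, whether a pyridine bearing a carboxylic acid or an amine in place of trifluoromethyl would stay at this level remains open.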